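Working notes on the step to compound 4

A few compounds are considered here, and "the series" means these few. Any claim that something is new, unique, unknown or untested is made for them only; others in the source may bear on it.

In a functional assay on MDA-MB-231 cells (Homo sapiens) for inhibition, read by CCK-8 assay, with a stated time of 48 h (a higher number here means a weaker inhibitor of growth, a lower number a stronger inhibitor of growth), three compounds have been read so far. Compound 1 (`Cc1ccccc1Nc1nc(NC2CCCCC2)ncc1Cl`) gives > 100000 nM as its reading, which is a limit of the assay and not a number. Compound 2 (`Cc1ccccc1Nc1nc(Nc2ccc(N3CCCCC3)cc2)ncc1Cl`) gives 19900 nM as a measured number. Compound 3 (`CN1CCN(c2ccc(Nc3ncc(Cl)c(Nc4ccccc4)n3)nc2)CC1`) gives 37400 nM as a measured number. Among the measured compounds shown here, the numbers of compound 2 and compound 3 lie within the usual scatter of each other and cannot be ranked, so compound 3 sits level with the only other number.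

Compound 4 (`COc1ccccc1CNc1nc(Nc2ccc(N3CCN(C)CC3)cn2)ncc1Cl`) has not yet been measured. Relative to compound 3 it carries 2-methoxybenzyl in place of phenyl on a nitrogen on an aromatic ring, so anilino becomes (2-methoxybenzyl)amino.

For the measured compounds named here, no measured pair isolates this change, so the expectation is loose and rests mainly on compound 3 at 37400 nM as its anchor. The estimated step is a 2.5-fold lower number from compound 3 to compound 4 (0.40 log units; beyond the scatter) in this assay and is expected to lie only slightly beyond the scatter, towards a lower number, with the opposite direction not excluded. For compound 4 the estimated value is 15000 nM with an expected range from 3000 nM to 60000 nM as the working figure.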

Compound 4, concentration for 50% growth inhibition: 29300 nM
For compound 4 the middle estimate is 2.0-fold (0.29 log units) below the measured one, and the stated range covers the measured number.
By their numbers in this assay, from the lowest: compounds 2, 4 and 3 (each within the scatter of the next). At a limit, above all of these: compound 1.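

In this assay, among the compounds shown here, the first comparison that differs in one place reads as a 1.3-fold lower number from compound 3 to compound 4 (0.11 log units; within the scatter), with 2-methoxybenzyl in place of phenyl on a nitrogen on an aromatic ring. This position therefore accepts the exchange of phenyl for 2-methoxybenzyl, with its oxygen and hydrogen-bond acceptor, without a readable change in growth inhibition in this series. The step is read between two measured numbers, and the only reading at a limit belongs to compound 1: the limit of > 100000 nM in this assay, at which 1 of the 4 values shown sits.

The step combines the change from anilino to a benzylamino link with the addition of the methoxy group, so the contribution of each remains unresolved, and an unsubstituted benzyl on the same nitrogen would separate them. Also open, from the compounds shown here alone, is whether this position stays as unresponsive with a different kind of group, such as a simple methyl, or a longer chain ending in an amine or a carboxylic acid, on the same core.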